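The compounds below may be only part of what the source reports. "The series", "measured", "known", "first", "only" and "open" are said of these compounds alone.

Measured so far:
- compound 1 `CSc1nccc2c1ncn2C1O[C@H](CO)[C@@H](O)[C@H]1O` — 24%
- compound 2 `Sc1[nH]ccc2ncnc1-2` — 26%

In a functional assay (Homo sapiens) for inhibition of Nucleic Acid, tested at 100 uM (a higher number here means more inhibition at the concentration tested (going by the name of the read-out), a lower number less inhibition), compound 1 gives 24%. Compound 2, which lacks the sugar and carries a free thiol on the same core, gives 26% in this assay. Compound 1 stands at the bottom of the two numbers, yet the gap to compound 2 is within the scatter, so the two cannot be told apart on these readings. Within the data shown here, no pair among the measured compounds differs in a single place, so no measured step is available from which to read the effect of a change at the core.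

Compound 3 `OC[C@H]1OC(n2cnc3c(Nc4ccccc4)nccc32)[C@H](O)[C@@H]1O` is the next compound of the series to be run in this assay. Relative to compound 1 the change is anilino in place of methylsulfanyl on an aromatic carbon.

Among the measured compounds shown here, with no measured step to lean on and both known compounds sitting low in this assay, the expectation for the step of a number 4 percentage points higher from compound 1 to compound 3 (within the scatter) is none beyond the scatter, in either direction. On that basis compound 3 is estimated at 28% in this assay, within a range of 5% to 55%.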

Compound 3, a percentage reported as inhibition, at one concentration (the size of the read-out at that concentration, not a potency): 4%
Compound 3: the middle estimate sits 24 percentage points above what was measured; the measured number lies below the stated range.
By their numbers in this assay, from the lowest: compound 3; then compounds 1 and 2 (each within the scatter of the next).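

In this assay, among these compounds, replacing methylsulfanyl with anilino on the aromatic carbon next to the ring nitrogen gives the first readable step (a number 20 percentage points lower from compound 1 to compound 3 (beyond the scatter)), so this position is not indifferent to what it carries. The change is a composite one: the entering group brings more heavy atoms, a six-membered aromatic ring of carbon only and a hydrogen-bond donor, while the sulfur leaves, and this single step cannot separate those differences. No measurement at hand offers an explanation for the step.

Going by these compounds, it remains open which part of the exchange matters, and a plain amino group, a methylamino group or a benzylamino group at the same carbon would divide the question between the nitrogen link, the aromatic ring and its distance from the core, while ethylsulfanyl would test a longer chain on sulfur. On these data alone, the part played by the sugar also stays open, since compound 2 differs from compound 1 and compound 3 in more than one place.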